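The source may report more compounds than this note shows. Statements on the series, on what has been measured and on what is new or still open speak of the compounds shown alone.

Compound 1 `O=C(Nc1cccc(/C=C/C(=O)c2nc3ccccc3[nH]2)c1)c1cccc(Cl)c1` gives 7840 nM in a functional assay on MCF7 cells (Homo sapiens) for antiproliferative activity, read by MTT assay, with a stated time of 48 h; on this read-out higher numbers stand for weaker inhibition and lower numbers for stronger inhibition.
Compound 2 `COc1cccc(C(=O)Nc2cccc(/C=C/C(=O)c3nc4ccccc4[nH]3)c2)c1` gives 17800 nM in this assay.
Compound 3 `O=C(/C=C/c1cccc(NS(=O)(=O)c2ccc(Cl)cc2)c1)c1nc2ccccc2[nH]1` gives 3820 nM in this assay.

Compound 3 holds the lowest number of the three, as both a 2.1-fold lower number from compound 1 to compound 3 (0.31 log units; beyond the scatter) and a 4.7-fold lower number from compound 2 to compound 3 (0.67 log units; beyond the scatter) lie beyond the scatter. Compound 4 `Cc1cc(C)cc(S(=O)(=O)Nc2cccc(/C=C/C(=O)c3nc4ccccc4[nH]3)c2)c1` differs from compound 3 in one place: 3,5-dimethylphenyl in place of 4-chlorophenyl on a sulfonyl sulfur. Among the compounds with values here, only one measured step changes a substituent on this outer ring, a 2.3-fold higher number from compound 1 to compound 2 (0.36 log units; beyond the scatter), and there chloro also left. The other two steps swap carbonyl for sulfonyl and say nothing about ring substituents. With chloro leaving again, a modest rise in number, or none beyond the scatter, is expected. Compound 4 is expected at 6000 nM, with a range from 2500 nM to 15000 nM. The expected step is a 1.6-fold higher number from compound 3 to compound 4 (0.20 log units; within the scatter).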

Compound 4, half-maximal inhibitory concentration: 4570 nM
The estimate for compound 4 lay 1.3-fold (0.12 log units) above the measured number; low and high end bracket the measured number.
By their numbers in this assay, from the lowest: compounds 3, 4 and 1 (each within the scatter of the next, the first and the last beyond it); then compound 2.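

On the sulfonyl sulfur in this assay, 3,5-dimethylphenyl and 4-chlorophenyl read alike (a 1.2-fold higher number from compound 3 to compound 4 (0.08 log units; within the scatter)). So losing chloro from this outer ring does not always move the number beyond the scatter, as it did when methoxy replaced chloro in the carbonyl-linked pair (a 2.3-fold higher number from compound 1 to compound 2 (0.36 log units; beyond the scatter)). Nothing available explains why these two sulfonamides match. Chloro left and two methyl groups entered in a single step, so the effect of each alone stays unknown. Also open, as far as these compounds go, is how this position would respond to an amine or a carboxylic acid on the ring.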